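The source may report more compounds than this note shows. Statements on the series, on what has been measured and on what is new or still open speak of the compounds shown alone.

In a functional assay on NCI-H460 cells (Homo sapiens) for inhibition, with a stated time of 72 h (on this read-out lower numbers stand for stronger inhibition and higher numbers for weaker inhibition), compound 1 (`COc1ccc(S(=O)(=O)N2CCc3cccc(-c4ccc(F)cc4)c32)cc1`) gives 95.5 nM and compound 2 (`COc1ccc(S(=O)(=O)n2ccc3cccc(-c4ccc(C#N)cc4)c32)cc1`) gives 172 nM on the same read-out. These two numbers lie within the usual scatter of each other, so compound 1 stands level with compound 2 and the two cannot be told apart.

Compound 3 (`COc1ccc(S(=O)(=O)N2CCc3cccc(-c4ccc(C#N)cc4)c32)cc1`) keeps the core of compound 1 and changes one group (cyano in place of fluoro on an aromatic carbon), para to a large group, turning 4-fluorophenyl into 4-cyanophenyl. Among the compounds with values here, no measured pair shows this exchange on its own, so its size cannot be read directly. Within the data shown here, the one hint is compound 2, which also carries 4-cyanophenyl and in this assay reads 172 nM (within the scatter of compound 1). The expected change in this assay is therefore small, leaning slightly toward weaker inhibition and probably not beyond the scatter (a 1.4-fold higher number from compound 1 to compound 3 (0.13 log units; within the scatter)). In this assay the estimated value for compound 3 is 130 nM with an expected range from 45 nM to 380 nM as the likely span.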

Compound 3, half-maximal inhibitory concentration: 29.5 nM
Compound 3: middle estimate off by 4.4-fold (0.64 log units), on the high side; the whole stated range lies above it.
By their numbers in this assay, from the lowest: compound 3; then compounds 1 and 2 (each within the scatter of the next).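

In this assay, the exchange on the core of compound 1 is not neutral: cyano in place of fluoro gives a 3.2-fold lower number from compound 1 to compound 3 (0.51 log units; beyond the scatter), and a lower number here means stronger inhibition, so the group para to a large group clearly matters to the read-out. The 4-cyanophenyl group does not settle the value on its own, since compound 2 carries it on a different core and gives 172 nM, while compound 3 gives 29.5 nM. Nothing measured here accounts for the gain in compound 3.

From the compounds shown here alone, with only fluoro and cyano to compare at this place, it remains open whether another group there, such as trifluoromethyl, an amine or a carboxylic acid, would lower the number further, leave it unchanged or raise it. It also remains open whether the same exchange would give a step of similar size on the core of compound 2, as the compounds shown offer no such pair.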